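The compounds below may be only part of what the source reports. "The series", "measured", "known", "first", "only" and "open" are said of these compounds alone.

Working notes on the series, read in a functional assay on HL-60 cells (Homo sapiens) for cytotoxicity, read by MTT assay, with a stated time of 3 days; on this read-out higher numbers stand for weaker inhibition and lower numbers for stronger inhibition: compound 1 (`N#Cc1c(O)nc(SCc2nc3ccccc3[nH]2)nc1-c1ccccc1`) gives 2.55 nM, compound 2 (`N#Cc1c(NNC(N)=S)nc(SCc2nc3ccccc3[nH]2)nc1-c1ccccc1`) gives 4.54 nM and compound 3 (`N#Cc1c(NC(N)=S)nc(SCc2nc3ccccc3[nH]2)nc1-c1ccccc1`) gives 5.81 nM. Compound 3 and compound 2 lie within the scatter of each other at the high end of these numbers. Within the data shown here, the one step beyond the scatter, and only modestly so, is a 2.3-fold higher number from compound 1 to compound 3 (0.36 log units; beyond the scatter). The other two steps at this group are a 1.8-fold higher number from compound 1 to compound 2 (0.25 log units; within the scatter) and a 1.3-fold higher number from compound 2 to compound 3 (0.11 log units; within the scatter).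

Next is compound 4 (`N#Cc1c(-c2ccccc2)nc(SCc2nc3ccccc3[nH]2)nc1N1CCNCC1`), with the change (a group of 6 heavy atoms (4 carbon, 2 nitrogen; one six-membered non-aromatic ring with 2 hetero atoms) in place of a group of 4 heavy atoms (1 carbon, 2 nitrogen, 1 sulfur; no ring), on an aromatic carbon). Going by these compounds, all three measured steps are small, but none of them brings in a ring, so the piperazin-1-yl group is untested and the range has to stay wide. In this assay no step beyond the scatter is expected, in either direction. The estimated change is a 1.2-fold lower number from compound 3 to compound 4 (0.07 log units; within the scatter). For compound 4 the expected value is 5 nM, within an estimated range of 1.5 nM to 20 nM.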

Compound 4, half-maximal inhibitory concentration: 4 nM
Compound 4: middle estimate off by 1.3-fold (0.10 log units), on the high side, and the stated range covers the measured number.
By their numbers in this assay, from the lowest: compounds 1, 4, 2 and 3 (each within the scatter of the next, the first and the last beyond it).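

Among these compounds, at this aromatic carbon, piperazin-1-yl is the first ring tested, and in this assay its replacement of the earlier groups gives three steps that all lie within the scatter (a 1.5-fold lower number from compound 3 to compound 4 (0.16 log units; within the scatter); a 1.1-fold lower number from compound 2 to compound 4 (0.05 log units; within the scatter); a 1.6-fold higher number from compound 1 to compound 4 (0.20 log units; within the scatter)). The position therefore accepts a six-membered non-aromatic ring with 2 hetero atoms without a step beyond the scatter from hydroxy or from either of the two groups without a ring, although compound 1 and compound 3 remain beyond the scatter of each other. The data shown offer no measured reason for this result.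

Going by these compounds, it remains open whether morpholin-4-yl, piperidin-1-yl or an open-chain amine such as dimethylamino would stay within this band at the same carbon. On these data alone, it also remains open whether N-methylpiperazin-1-yl would read like compound 4, or whether the picture would hold with a group other than phenyl on the core.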